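This account rests on a few compounds, and the source may have more. Where it says the series, first, only, none or still open, it means among the compounds named here.

Compound 3 `CCC(C)(C)Cc1c[nH]c(CCc2ccc(-c3csnn3)cc2)n1`: 538 nM
Compound 2 `CCC(C)(C)Cc1c[nH]c(CCc2ccc(-c3cnccn3)cc2)n1`: 431 nM
Compound 1 `CCC(C)(C)Cc1c[nH]c(CCc2ccc(-c3cccc(C)n3)cc2)n1`: 105 nM

In a functional assay on HEK293 cells for agonist activity at Bombesin receptor subtype-3 (Homo sapiens), read by luminescence and calcium flux, with a stated time of 10 min (on this read-out lower numbers stand for an effect already at smaller amounts and higher numbers for an effect only at larger amounts of compound), compound 3 gives the highest of the three numbers; its nearest neighbour is compound 2, and the step of a 1.2-fold higher number from compound 2 to compound 3 (0.10 log units; within the scatter) lies within the scatter, while the step of a 5.1-fold higher number from compound 1 to compound 3 (0.71 log units; beyond the scatter) is beyond it. Compound 4 `CCC(C)(C)Cc1c[nH]c(CCc2ccc(-n3cncn3)cc2)n1` differs from compound 3 in one place: 1H-1,2,4-triazol-1-yl in place of 1,2,3-thiadiazol-4-yl on an aromatic carbon. The step that bears most on this change is the one between two small five-membered or six-membered heteroaryl groups of similar size, a 1.2-fold higher number from compound 2 to compound 3 (0.10 log units; within the scatter), which was within the scatter; the steps of a 4.1-fold higher number from compound 1 to compound 2 (0.61 log units; beyond the scatter) and a 5.1-fold higher number from compound 1 to compound 3 (0.71 log units; beyond the scatter) show that the methylpyridyl group is the only one so far to give a clearly lower number. Exchanging one three-heteroatom five-membered ring for another is therefore expected to give a step within the scatter, a 1.1-fold lower number from compound 3 to compound 4 (0.03 log units; within the scatter). For compound 4 the estimate is 500 nM, within a range from 200 nM to 1300 nM.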

Compound 4, half-maximal effective concentration: 570 nM
Compound 4: middle estimate off by 1.1-fold (0.06 log units), on the low side; low and high end bracket the measured number.
By their numbers in this assay, from the lowest: compound 1; then compounds 2, 3 and 4 (each within the scatter of the next).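

In this assay, replacing 1,2,3-thiadiazol-4-yl with 1H-1,2,4-triazol-1-yl trades sulfur for nitrogen and attaches the ring through nitrogen rather than carbon, yet the result (a 1.1-fold higher number from compound 3 to compound 4 (0.03 log units; within the scatter)) shows no separation at this position. The comparison with pyrazin-2-yl (a 1.3-fold higher number from compound 2 to compound 4 (0.12 log units; within the scatter)) likewise shows none, while 6-methylpyridin-2-yl remains apart (a 5.4-fold higher number from compound 1 to compound 4 (0.73 log units; beyond the scatter)). Nothing available explains these results. Still open, as far as these compounds go, is whether the methyl group is needed for the lower number of compound 1, which unsubstituted pyridin-2-yl or 6-methylpyrazin-2-yl could test. From the compounds shown here alone, the effect of an amine or a carboxylic acid on this ring also remains open.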